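Working notes: one chloro leaves compound 3

The source may report more compounds than this note shows. Statements on the series, on what has been measured and on what is new or still open speak of the compounds shown alone.

Measured so far in a functional assay on DU-145 cells (Homo sapiens) for inhibition (on this read-out higher numbers stand for weaker inhibition of growth and lower numbers for stronger inhibition of growth), for this series
- compound 1 `O=S(=O)(/C=C/c1ccccc1)Cc1ccc(Nc2ncnc3ccccc23)cc1` gives 2000 nM as a number
- compound 2 `O=S(=O)(/C=C/c1ccc(Cl)cc1)Cc1ccc(Nc2ncnc3ccccc23)cc1` gives > 100000 nM as a limit
- compound 3 `O=S(=O)(/C=C/c1ccc(Cl)c(Cl)c1)Cc1ccc(Nc2ncnc3ccc(Br)cc23)cc1` gives 17000 nM as a number

Compound 3 at 17000 nM is the higher of the two actual numbers in this assay and its gap to compound 1 lies beyond the scatter. Compound 4 `O=S(=O)(/C=C/c1ccc(Cl)cc1)Cc1ccc(Nc2ncnc3ccc(Br)cc23)cc1` differs from compound 3 by hydrogen in place of chloro on an aromatic carbon with hydrogen in place of chloro on an aromatic carbon, so 3,4-dichlorophenyl becomes 4-chlorophenyl.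

Among the compounds with values here, the one measured step bearing on this is an at least 50-fold higher number from compound 1 to compound 2 (1.69 log units; beyond the scatter) with chloro in place of hydrogen on an aromatic carbon. Read backwards, that large step would point to a lower number. It does not carry over directly, however, since compound 2 already holds the 4-chlorophenyl group that compound 4 keeps. Since compound 4 shares that group with compound 2 at the limit of > 100000 nM in this assay, at which 1 of the 3 values shown sits, a small rise in the number is expected rather than a fall, and a report only as a limit stays possible. The estimated move is a 2.4-fold higher number from compound 3 to compound 4 (0.37 log units; beyond the scatter) and is expected to be small. In this assay the estimate for compound 4 is 40000 nM with an expected range of 10000 nM to 100000 nM for now.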

Compound 4, concentration for 50% growth inhibition: 1000 nM
For compound 4 the middle estimate is 40-fold (1.60 log units) above the measured one; the measured number lies below the stated range.
By their numbers in this assay, from the lowest: compounds 4 and 1 (each within the scatter of the next); then compound 3. At a limit, above all of these: compound 2.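

Hydrogen in place of chloro at this place, on an aromatic carbon ortho to a chloro group and meta to a large group, is a large change in this assay: a 17-fold lower number from compound 3 to compound 4 (1.23 log units; beyond the scatter), so 3,4-dichlorophenyl and 4-chlorophenyl are clearly separated on the bromo-bearing core. The 4-chlorophenyl group therefore does not by itself set a poor read-out, as bromo in place of hydrogen on the core gives an at least 100-fold lower number from compound 2 to compound 4 (2.00 log units; beyond the scatter), although this step starts from a limit of the assay and its full size cannot be read. Chloro in place of hydrogen raises the number in both pairs that can be compared, but the size of the rise depends on the pair: the same change on two cores in this assay, an at least 50-fold higher number (1.69 log units; beyond the scatter) from compound 1 to compound 2 and a 17-fold higher number (1.23 log units; beyond the scatter) from compound 4 to compound 3, at least 2.9-fold (0.46 log units) apart, beyond the scatter of two such steps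

As far as these compounds go, whether an amine or a methoxy group at the same place would read like hydrogen or like chloro remains open, as does the effect of a chloro at this place on the core without bromo. The effect of bromo on the unsubstituted phenyl compound also remains open, so the compounds shown cannot say whether bromo helps only when the 4-chlorophenyl group is present.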